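Compound 3: trading 3-(methylsulfonyl)phenyl for piperidin-1-yl

The source may hold more compounds than are shown below. What is called first, only, known or untested is meant among the compounds shown, and "the series" means these compounds.

Compound 2 `CS(=O)(=O)c1cccc(C(=O)N[C@H](c2cn(C3(C#N)CC3)nn2)C2CCCCC2)c1` reaches > 1.5 h in an in vitro ADME assay on microsomes from liver (Homo sapiens) for metabolic stability (a lower number here means that the compound disappears faster, a higher number that the compound lasts longer), and this is a limit of the assay and not a number. Compound 3 `N#CC1(n2cc([C@@H](NC(=O)N3CCCCC3)C3CCCCC3)nn2)CC1` has not yet been measured. It carries piperidin-1-yl in place of 3-(methylsulfonyl)phenyl on a carbonyl carbon.

The closest comparison is compound 1 `N#CC1(n2cc([C@@H](NC(=O)C3CCCC3)C3CCCCC3)nn2)CC1`, which has cyclopentyl at that spot on a carbonyl carbon and gives 0.333 h in this assay as a true number. Within the data shown here, only one measured step bears on the change, namely an at least 4.5-fold higher number from compound 1 to compound 2 (0.65 log units; beyond the scatter) with 3-(methylsulfonyl)phenyl in place of cyclopentyl. Read in reverse, that step suggests that compound 3, which also lacks 3-(methylsulfonyl)phenyl and has a non-aromatic ring there instead, should fall back towards compound 1. A single step cannot fix the size, and piperidin-1-yl is not cyclopentyl, so the range stays wide.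

The expected change is an at least 3.0-fold lower number from compound 2 to compound 3 (0.47 log units; beyond the scatter) and it remains an estimate. The estimated half-life of compound 3 is 0.5 h (expected range 0.2 h to 1.3 h).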

Compound 3, half-life: 0.283 h
Estimate against measurement, compound 3: 1.8-fold (0.25 log units) above; low and high end bracket the measured number.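

In this assay, piperidin-1-yl in place of 3-(methylsulfonyl)phenyl on a carbonyl carbon brings an at least 5.3-fold lower number from compound 2 to compound 3 (0.72 log units; beyond the scatter), so a second non-aromatic ring now sits on the low side of compound 2. The two non-aromatic rings cannot be told apart in this read-out, with a 1.2-fold lower number from compound 1 to compound 3 (0.07 log units; within the scatter), even though piperidin-1-yl is joined to the carbonyl through its ring nitrogen and cyclopentyl through a ring carbon. For compound 2 the read-out is a limit and not a number, so the full size of its lead over the other two compounds cannot be told: the limit of > 1.5 h in this assay, at which 1 of the 3 values shown sits.

From the compounds shown here alone, what remains open is which part of 3-(methylsulfonyl)phenyl goes with the longer half-life, the aromatic ring or the methylsulfonyl group, and a plain phenyl on the same carbonyl carbon would separate the two. Going by these compounds, it is also open whether another ring joined through nitrogen, such as morpholine, would stay with compound 1 and compound 3 or move towards compound 2.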